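Cytotoxicity notes on the shared core: amine variation

The source may report more compounds than this note shows. Statements on the series, on what has been measured and on what is new or still open speak of the compounds shown alone.

Measured so far in an ADME assay on MT4 cells (Homo sapiens) for cytotoxicity, read by MTT assay, with a stated time of 5 days; on this read-out higher numbers stand for lower toxicity in this test and lower numbers for higher toxicity in this test:
- Compound 1 `CCCC(CCC)Nc1cc(Oc2c(OC)cc3cc(C#N)ccc3c2OC)nc(Nc2ccc(C#N)cc2)n1` gives > 125000 nM, a limit of the assay.
- Compound 2 `COc1cc2cc(C#N)ccc2c(OC)c1Oc1cc(NCC2CCOCC2)nc(Nc2ccc(C#N)cc2)n1` gives > 125000 nM, also a limit.
- Compound 3 `COc1cc2cc(C#N)ccc2c(OC)c1Oc1cc(NC2CCOC2)nc(Nc2ccc(C#N)cc2)n1` gives > 125000 nM, also a limit.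

Compound 1 therefore stands only at a limit, not at a number, and the same holds for its two neighbours: all three sit at the limit of > 125000 nM in this assay, at which 3 of the 3 values shown sit. The measured steps a step that the two limits leave unreadable from compound 1 to compound 2, a step that the two limits leave unreadable from compound 1 to compound 3 and a step that the two limits leave unreadable from compound 2 to compound 3 are thus unreadable in size; none of them shows a change in this assay.

Compound 4 `COc1cc2cc(C#N)ccc2c(OC)c1Oc1cc(N2CCC(O)C2)nc(Nc2ccc(C#N)cc2)n1` differs from compound 1 as follows: 3-hydroxypyrrolidin-1-yl in place of (1-propylbutyl)amino on an aromatic carbon. All comparable changes on this nitrogen left the read-out at the limit, so no readable step is expected here either; the estimated step is a step that the limit leaves unreadable from compound 1 to compound 4. For compound 4 the expected value is 150000 nM, within 60000 nM to 400000 nM, most probably again reported only as a limit.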

Compound 4, half-maximal cytotoxic concentration: > 125000 nM
Compound 4: a limit, no number; the forecaster's own chance of this, stated with the estimate: 85%; the middle value does not contradict the limit.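

In this assay compound 4 gives > 125000 nM, a limit, so its steps from compound 1, compound 2 and compound 3 cannot be read: the limit of > 125000 nM in this assay, at which 4 of the 4 values shown sit.

On these data alone, whether these amine groups differ at all on this read-out stays open, as none of the four compounds gives a number.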